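Sulfamoyl for Nitro: Expected Paw Edema Inhibition of Compound 4

The source may hold more compounds than are shown below. What is called first, only, known or untested is meant among the compounds shown, and "the series" means these compounds.

Compound 1 `O=c1c2c(Nc3ccccc3)nn(-c3ccc([N+](=O)[O-])cc3)c2nc(Nc2ccccc2)n1-c1ccccc1`: 43.9%
Compound 2 `NS(=O)(=O)c1ccc(-n2nc(Nc3ccccc3)c3c(=O)n(-c4ccccc4)c(Nc4ccccc4)nc32)cc1`: 60.2%
Compound 3 `Cc1ccc(Nc2nn(-c3ccc([N+](=O)[O-])cc3)c3nc(Nc4ccccc4)n(-c4ccccc4)c(=O)c23)cc1`: 46.6%

Of the compounds shown here, three have been tested in a functional assay on the whole organism (strain Wistar albino) for inhibition, with Rattus norvegicus as the target, read by paw edema, with a stated time of 1 h, at a dose of 25 mg/kg by the oral route; on this read-out lower numbers stand for less inhibition and higher numbers for more inhibition at the one dose given (going by the name of the read-out). They share one core; compound 3 differs from compound 1 by methyl in place of hydrogen on an aromatic carbon, and that change gave a number 2.7 percentage points higher from compound 1 to compound 3 (within the scatter). Compound 2 differs from compound 1 by sulfamoyl in place of nitro on an aromatic carbon, a change that gave a number 16.3 percentage points higher from compound 1 to compound 2 (beyond the scatter). Compound 4 `Cc1ccc(Nc2nn(-c3ccc(S(N)(=O)=O)cc3)c3nc(Nc4ccccc4)n(-c4ccccc4)c(=O)c23)cc1` has not been measured; it differs from compound 3 by sulfamoyl in place of nitro on an aromatic carbon, the same change at the same place, now starting from compound 3. Because compound 3 sits near compound 1 with a number 2.7 percentage points higher from compound 1 to compound 3 (within the scatter), and the change gave a number 16.3 percentage points higher from compound 1 to compound 2 (beyond the scatter), a step of similar size is expected. The step from compound 3 to compound 4 in this assay is expected to be a number 15.4 percentage points higher from compound 3 to compound 4 (beyond the scatter). Compound 4 is estimated at 62%, with a likely range from 50% to 74%.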

Compound 4, a percentage reported as inhibition, in the whole organism at one dose (the size of the read-out at that dose, not a potency): 77%
Compound 4: the middle estimate sits 15 percentage points below what was measured, and the stated range ends below it.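

In this assay, sulfamoyl in place of nitro on the methyl-bearing core gave a number 30.4 percentage points higher from compound 3 to compound 4 (beyond the scatter), so the direction carried over from the earlier pair but the size did not: the same change on two cores in this assay, a number 16.3 percentage points higher (beyond the scatter) from compound 1 to compound 2 and a number 30.4 percentage points higher (beyond the scatter) from compound 3 to compound 4, 14.1 percentage points apart, beyond the scatter of two such steps

Read the other way, methyl in place of hydrogen gave a number 16.8 percentage points higher from compound 2 to compound 4 (beyond the scatter), a step beyond the scatter on the sulfamoyl compounds but not on the nitro compounds: the same change on two cores in this assay, a number 2.7 percentage points higher (within the scatter) from compound 1 to compound 3 and a number 16.8 percentage points higher (beyond the scatter) from compound 2 to compound 4, 14.1 percentage points apart, beyond the scatter of two such steps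

The two changes therefore do not simply add up across these four compounds, but the set shows neither why this is so nor whether the larger step would hold on any other core.

Only nitro and sulfamoyl appear at the first place and only hydrogen and methyl at the second. Going by these compounds, how a carboxylic acid or an amine at the first place, or a chlorine or a methoxy group at the second, would behave remains open.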